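The source may hold more compounds than are shown below. What is called first, only, known or untested is meant among the compounds shown, and "the series" means these compounds.

Measured compounds:
Compound 1 `C=CC1=C(C(=O)NCC(C)C)C(c2ccc(F)cc2)OC1`: in a functional assay on A549 cells (Homo sapiens) for cytotoxicity, read by MTT assay, with a stated time of 24 h (on this read-out lower numbers stand for stronger inhibition and higher numbers for weaker inhibition), compound 1 reaches only the assay limit of > 100000 nM.
Compound 2 `C=CC1=C(C(=O)NCc2ccccc2)C(c2ccc(F)cc2)OC1`: compound 2 likewise reaches only the assay limit of > 100000 nM.

Compound 1 thus stands at a limit, with no number read for it. Among the compounds with values here, the single known step, a step that the two limits leave unreadable from compound 1 to compound 2, cannot be sized because the limit of > 100000 nM in this assay, at which 2 of the 2 values shown sit, holds both values. Compound 3 `C=CC1=C(C(=O)NCC(C)C)C(c2ccc(OC)cc2)OC1` differs from compound 1 by methoxy in place of fluoro on an aromatic carbon. Within the data shown here, no measured step touches this position, so nothing indicates a change in this assay beyond the scatter. With compound 1 at the limit, compound 3 is expected to stay there as well, an expected step of a number no higher from compound 1 to compound 3 (the limit leaves the size open). The estimate for compound 3 is 100000 nM, between 30000 nM and 300000 nM.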

Compound 3, half-maximal inhibitory concentration: > 100000 nM
Compound 3 ended at the assay's limit; the forecaster's own chance of this, stated with the estimate: 85%; the middle value sits exactly at the limit.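

No step can be read from compound 1 to compound 3, since both values are limits and not numbers: the limit of > 100000 nM in this assay, at which 3 of the 3 values shown sit.

The compounds shown leave open whether any change to the shared core would give a readable number in this assay.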